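Shortening the Linker Chain in a Leukotriene Receptor Series

This account rests on a few compounds, and the source may have more. Where it says the series, first, only, none or still open, it means among the compounds named here.

Within the data shown here, compound 2 `COc1ccc(CCCCOc2ccc(CSc3c(Cl)cccc3Cl)nc2/C=C/C(=O)O)cc1` is one of two compounds measured in an assay on isolated protein for binding affinity to leukotriene B4 receptor 1 (Homo sapiens) (a higher number here means a weaker inhibitor, a lower number a stronger inhibitor), where compound 2 gives 1.5 nM. Among the measured compounds shown here, its only neighbour is compound 1 `COc1ccc(CCCCOc2ccc(CSc3ccccc3)nc2/C=C/C(=O)O)cc1`, which gives 2.8 nM in this assay; the step of a 1.9-fold lower number from compound 1 to compound 2 (0.27 log units; within the scatter) stays within the scatter. Compound 3 `COc1ccc(CCOc2ccc(CSc3c(Cl)cccc3Cl)nc2/C=C/C(=O)O)cc1` has not yet been measured. It differs from compound 2 by 4-methoxyphenyl in place of 2-(4-methoxyphenyl)ethyl on a saturated chain carbon, two bonds along the chain from an oxygen on an aromatic ring. For the measured compounds named here, the single measured step concerns the group on the sulfur, far from this chain, so it offers no direct guide, and no measured pair varies the chain itself. Going by the values given here, with no such precedent, a change in the length of the chain joining the two ring systems is expected to move the inhibition constant more than the sulfur step did, toward a weaker inhibitor, by a 10-fold higher number from compound 2 to compound 3 (1.00 log units; beyond the scatter). Compound 3 is therefore estimated at 15 nM, with a range from 3 nM to 80 nM.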

Compound 3, inhibition constant: 1.2 nM
Beside the measured number, compound 3's estimate is 13-fold (1.10 log units) above it, outside the stated range (below it).
By their numbers in this assay, from the lowest: compounds 3, 2 and 1 (each within the scatter of the next, the first and the last beyond it).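

In this assay, among these compounds, the step of a 1.3-fold lower number from compound 2 to compound 3 (0.10 log units; within the scatter) gives the first measured reading on the chain joining the two ring systems, which compound 1 and compound 2 share unchanged. At this position, on a saturated chain carbon, two bonds along the chain from an oxygen on an aromatic ring, replacing 2-(4-methoxyphenyl)ethyl with 4-methoxyphenyl therefore leaves the number within the scatter, so this one shortening shows no measurable loss of binding affinity. No evidence at hand speaks to what lies behind this result.

The compounds shown leave open whether the same holds for a longer chain, or for an amine or a carboxylic acid in place of the methoxy group. They also leave open whether the shorter chain behaves alike with plain phenyl on the sulfur.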